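This account rests on a few compounds, and the source may have more. Where it says the series, first, only, none or still open, it means among the compounds named here.

Compound 1 `c1csc(-c2ccccc2OCC2=NCCN2)c1` is the reference point of this small series. In a functional assay for activation of Alpha-1B adrenergic receptor (Homo sapiens), read by calcium flux (on this read-out lower numbers stand for an effect already at smaller amounts and higher numbers for an effect only at larger amounts of compound), compound 1 gives 3.98 nM. Compound 2 `Cc1cc(-c2ccccc2OCC2=NCCN2)sn1` carries a 3-methyl-1,2-thiazol-5-yl where compound 1 carries a thiophen-2-yl, on an aromatic carbon. For compound 2 this assay returns only a limit, < 100000 nM, and not a number. The step that the limit leaves unreadable from compound 1 to compound 2 therefore has no readable size, since the limit of < 100000 nM in this assay, at which 1 of the 2 values shown sits, shows that one of the two values is such a limit. Compound 3 `Cc1cnsc1-c1ccccc1OCC1=NCCN1` differs from compound 2 in one place: 4-methyl-1,2-thiazol-5-yl in place of 3-methyl-1,2-thiazol-5-yl on an aromatic carbon. Within the data shown here, no measured step bears directly on this change; the only known step, a step that the limit leaves unreadable from compound 1 to compound 2, is unreadable and concerns a different exchange. The position of the methyl on the 1,2-thiazol-5-yl is thus untested, and compound 2 itself stands only as a limit, so the size and direction of the change cannot be anchored. The expectation for compound 3 is accordingly wide: the step that the limit leaves unreadable from compound 2 to compound 3 is estimated only loosely, and compound 3 is expected to give 1000 nM in this assay, within a range from 30 nM to 30000 nM.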

Compound 3, half-maximal effective concentration: < 100000 nM
Compound 3 gave a limit, no number; the forecaster's own chance of this, stated with the estimate: 30%; the middle value lies beyond the limit too.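

Compound 3 also returns only a limit in this assay, so no new step can be read between compound 3 and either compound 1 or compound 2: the limit of < 100000 nM in this assay, at which 2 of the 3 values shown sit.

The compounds shown leave open how large the exchange of thiophen-2-yl for either methyl-1,2-thiazol-5-yl group is, and whether the position of the methyl matters at all in this assay.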